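Moving a hydroxyl group on a pyridine-linked phenyl ring

The compounds below may be only part of what the source reports. "The series", "measured", "known", "first", "only" and "open" are said of these compounds alone.

Of the compounds shown here, three sharing a common core have been measured so far. Compound 1 `Oc1ccc(-c2cc(-c3ccc(F)cc3)cc(-c3cccc(O)c3)n2)cc1` gives 5020 nM in a functional assay on HCT-15 cells (Homo sapiens) for inhibition; on this read-out lower numbers stand for stronger inhibition and higher numbers for weaker inhibition. Compound 2 `Oc1ccc(-c2cc(-c3ccc(F)cc3)cc(-c3ccc(O)cc3)n2)cc1` gives 4970 nM in this assay. The change between them is 4-hydroxyphenyl in place of 3-hydroxyphenyl on an aromatic carbon, and it produced a 1.0-fold lower number from compound 1 to compound 2 (0.00 log units; within the scatter). Compound 3 `Oc1cccc(-c2cc(-c3ccccc3C(F)(F)F)cc(-c3cccc(O)c3)n2)c1` gives 8150 nM in this assay; its core differs from that of compound 1 in a way that is not broken down here, and its value and those of compound 1 and compound 2 all lie within the usual scatter of one another.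

Compound 4 `Oc1ccc(-c2cc(-c3ccccc3C(F)(F)F)cc(-c3cccc(O)c3)n2)cc1` has not yet been measured. It differs from compound 3 by 4-hydroxyphenyl in place of 3-hydroxyphenyl on an aromatic carbon. Among the compounds with values here, this is the same kind of change as the one from compound 1 to compound 2, but the surroundings are not identical: in compound 3 the place of change is meta to a 2-(trifluoromethyl)phenyl group and meta to a 3-hydroxyphenyl group, whereas in compound 1 it is meta to a 4-fluorophenyl group and meta to a 4-hydroxyphenyl group.

Because the earlier change gave a 1.0-fold lower number from compound 1 to compound 2 (0.00 log units; within the scatter), the step from compound 3 to compound 4 is expected to be small, about a 1.0-fold lower number from compound 3 to compound 4 (0.01 log units; within the scatter). Compound 4 is therefore estimated to give 8000 nM in this assay, with a range from 4000 nM to 16000 nM.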

Compound 4, half-maximal inhibitory concentration: 5740 nM
Estimate against measurement, compound 4: 1.4-fold (0.14 log units) above; measured number inside the range.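

In this assay, putting 4-hydroxyphenyl in place of 3-hydroxyphenyl gave a 1.4-fold lower number from compound 3 to compound 4 (0.15 log units; within the scatter), and set beside the earlier case, the change behaves alike on the two cores: the same change on two cores in this assay, a 1.0-fold lower number (0.00 log units; within the scatter) from compound 1 to compound 2 and a 1.4-fold lower number (0.15 log units; within the scatter) from compound 3 to compound 4, 1.4-fold (0.15 log units) apart, within the scatter of two such steps

The other new comparison, 2-(trifluoromethyl)phenyl in place of 4-fluorophenyl, gave a 1.1-fold higher number from compound 1 to compound 4 (0.06 log units; within the scatter), so exchanging that group also left a step no larger than repeat measurements can produce. This shows only that the hydroxyl shift made no step beyond the scatter on these two cores; it does not show that the shift has a real effect of some shared size, that the position of the hydroxyl group is unimportant in general, or that the same would hold on a third core.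

The compounds shown leave open which changes, if any, would move the number beyond the scatter, since every step here lies within it. Replacing a hydroxyl group with a methoxy group, an amine or a carboxylic acid would test whether the hydroxyl groups matter at all, a question that moving them around cannot answer.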